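A Bulkier Amine on a Shared Core, Still Untested

A few compounds are considered here, and "the series" means these few. Any claim that something is new, unique, unknown or untested is made for them only; others in the source may bear on it.

Compound 2 `COc1cc(/C=C/c2nc(N(C)C)c3sccc3n2)cc(OC)c1OC` and compound 1 `CN1CCN(c2nc(/C=C/c3ccco3)nc3ccsc23)CC1` share a fused core and were both tested in a functional assay on L02 cells (Homo sapiens) for inhibition, read by Griess assay, with stated times of 1 h and 24 h; a higher number here means a weaker inhibitor, a lower number a stronger inhibitor. For compound 1 the assay returned only a limit, > 1000000 nM, not a number. For compound 2 the result is again only a limit, > 1000000 nM. Compound 2 thus stands at the limit of > 1000000 nM in this assay, at which 2 of the 2 values shown sit, so nothing yet distinguishes the two measured compounds from each other.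

Compound 3 `COc1cc(/C=C/c2nc(NCc3ccccc3Cl)c3sccc3n2)cc(OC)c1OC` differs from compound 2 in one place: (2-chlorobenzyl)amino in place of dimethylamino on an aromatic carbon. Among the compounds with values here, no measured pair differing in a single place is available, so no step can serve as a guide. A change of this kind could move the value in either direction, but with both measured compounds at the limit, the most likely outcome in this assay is a movement that stays within the usual scatter, or none at all.

Compound 3 is therefore expected to give about 700000 nM, within 100000 nM to 3000000 nM. The expected step of an at least 1.4-fold lower number from compound 2 to compound 3 (0.15 log units; that floor lies within the scatter) is small, and a result reported only as a limit would not be surprising.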

Compound 3, half-maximal inhibitory concentration: > 1000000 nM
Compound 3: no number, only a limit; the forecaster's own chance of this, stated with the estimate: 70%; middle value at least 1.4-fold (0.15 log units) away from the limit.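

In this assay compound 3 gives > 1000000 nM, a limit and not a number. Compound 2 also gives only a limit, so no step can be read between compound 2 and compound 3: the limit of > 1000000 nM in this assay, at which 3 of the 3 values shown sit. The compounds shown leave open how (2-chlorobenzyl)amino and dimethylamino compare, and whether any compound on this shared core gives a measurable number in this assay.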